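Acylating the Ring Amine of a Tetrahydroisoquinoline Amide

The source may report more compounds than this note shows. Statements on the series, on what has been measured and on what is new or still open speak of the compounds shown alone.

Measured compounds:
compound 1, `O=C(Nc1ccc(O)cc1)C1NCCc2ccccc21`: 4370 nM
compound 2, `COc1ccccc1NC(=O)C1NCCc2ccccc21`: > 10000 nM

Among the measured compounds shown here, in a functional assay on NUGC-3 cells (Homo sapiens) for inhibition, read by sulforhodamine B assay, with a stated time of 48 h (on this read-out lower numbers stand for stronger inhibition of growth and higher numbers for weaker inhibition of growth), compound 1 gives 4370 nM, the only plain number among the two values shown. For compound 2 the value is a limit of the assay, > 10000 nM, as noted in the limit of > 10000 nM in this assay, at which 1 of the 2 values shown sits. The untested compound 3, `O=C(Nc1ccc(O)cc1)C1c2ccccc2CCN1C(=O)c1ccc(Cl)cc1`, carries (4-chlorophenyl)carbonyl in place of hydrogen on an amine nitrogen in a ring. For the measured compounds named here, no measured pair shows a step of this kind, so the expectation rests on the structural change alone. A moderate step toward stronger inhibition is expected, a 2.2-fold lower number from compound 1 to compound 3 (0.34 log units; beyond the scatter), though a result within the usual scatter would not surprise. Compound 3 is estimated at 2000 nM, ranging from 300 nM to 10000 nM.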

Compound 3, concentration for 50% growth inhibition: > 10000 nM
Compound 3 gave a limit, no number; the forecaster's own chance of this, stated with the estimate: 25%; at least 5.0-fold (0.69 log units) between middle value and limit.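

Replacing the hydrogen on this amine nitrogen in a ring with (4-chlorophenyl)carbonyl gives an at least 2.2-fold higher number from compound 1 to compound 3 (0.35 log units; beyond the scatter), so this change weakens growth inhibition rather than strengthening it. For compound 3 the value > 10000 nM is a limit, so that step gives only a minimum size. Compound 3 now shares the upper end of the read-out with compound 2: the limit of > 10000 nM in this assay, at which 2 of the 3 values shown sit.

As far as these compounds go, whether a smaller group on this nitrogen, such as acetyl or methyl, would keep the inhibition of compound 1 remains open. The compounds shown also do not tell whether the chlorine or the carbonyl matters more.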